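Methyl on the Piperazine Ring and Vero Cell Cytotoxicity

This account rests on a few compounds, and the source may have more. Where it says the series, first, only, none or still open, it means among the compounds named here.

Compound 2 `O=c1nc(N2CCN(CC3CCCCC3)CC2)oc2c([N+](=O)[O-])cc(C(F)(F)F)cc12` and compound 1 `CC1CN(c2nc(=O)c3cc(C(F)(F)F)cc([N+](=O)[O-])c3o2)CCN1CC1CCCCC1` share a core and differ by methyl in place of hydrogen on a saturated ring carbon. In an ADME assay on Vero cells (Chlorocebus sabaeus) for cytotoxicity, read by MTT assay, with a stated time of 48 h (a lower number here means a stronger inhibitor, a higher number a weaker inhibitor), compound 2 gives 52.1 ug/mL. In this assay compound 1 gives 10.9 ug/mL, so the change made a 4.8-fold lower number from compound 2 to compound 1 (0.68 log units; beyond the scatter). Compound 3 `O=c1cc(N2CCN(CC3CCCCC3)CC2)sc2c([N+](=O)[O-])cc(C(F)(F)F)cc12` carries a different core, and the difference between the two cores is not broken down here. In this assay compound 3 reaches only a limit, > 64 ug/mL, as noted in the limit of > 64 ug/mL in this assay, at which 1 of the 3 values shown sits. Compound 4 `CC1CN(c2cc(=O)c3cc(C(F)(F)F)cc([N+](=O)[O-])c3s2)CCN1CC1CCCCC1` arises from compound 3 by methyl in place of hydrogen on a saturated ring carbon, the same change as from compound 2 to compound 1. For compound 4 the expected step is an at least 1.8-fold lower number from compound 3 to compound 4 (0.26 log units; that floor lies within the scatter), which rests on the earlier step of a 4.8-fold lower number from compound 2 to compound 1 (0.68 log units; beyond the scatter) and on the limit (the limit of > 64 ug/mL in this assay, at which 1 of the 3 values shown sits). Compound 4 is therefore estimated at 35 ug/mL, between 14 ug/mL and 64 ug/mL.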

Compound 4, half-maximal inhibitory concentration: > 64 ug/mL
Compound 4 gave a limit, no number; the forecaster's own chance of this, stated with the estimate: 35%; middle value at least 1.8-fold (0.26 log units) from the limit.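

Compound 3 and compound 4 both stand at a limit and not at a number, so no step can be read between them: the limit of > 64 ug/mL in this assay, at which 2 of the 4 values shown sit.

The compounds shown leave open whether methyl in place of hydrogen on a saturated ring carbon changes the reading on the core of compound 3 in this assay.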